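A few compounds are considered here, and "the series" means these few. Any claim that something is new, unique, unknown or untested is made for them only; others in the source may bear on it.

Compound 1 `O=C(/C=C/[C@H]1C[C@@H](O)[C@@H](O)C1)Nc1ccc(Cl)cc1`, compound 2 `O=C(/C=C/[C@H]1C[C@@H](O)[C@@H](O)C1)Nc1ccc(C(F)(F)F)cc1` and compound 3 `COc1ccc(NC(=O)/C=C/[C@H]2C[C@@H](O)[C@@H](O)C2)cc1` share one core and differ only in the group carried on the aromatic carbon. In an ADME assay on S2 cells (Drosophila melanogaster) for cytotoxicity, read by MTT assay (a higher number here means that more compound is needed for the effect, a lower number that less compound is needed), compound 1 gives > 180000 nM, which is a limit of the assay rather than a number. Compound 2 gives > 160000 nM in this assay, again a limit. Compound 3 likewise gives > 180000 nM, also a limit. Each value being a limit, the step that the two limits leave unreadable from compound 1 to compound 2, the step that the two limits leave unreadable from compound 1 to compound 3 and the step that the two limits leave unreadable from compound 2 to compound 3 cannot be read; all that is known is the limit of > 160000 nM in this assay, at which 1 of the 3 values shown sits, and (the limit of > 180000 nM in this assay, at which 2 of the 3 values shown sit). Compound 3 thus stands at a limit, as do both of the other measured compounds.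

Compound 4 `O=C(/C=C/[C@H]1C[C@@H](O)[C@@H](O)C1)Nc1ccc([N+](=O)[O-])cc1` differs from compound 3 in one place: nitro in place of methoxy on an aromatic carbon. Among the compounds with values here, none of the measured steps can be sized, so they give no direction for this change; the only guidance is that every compound so far sits at a limit in this assay. Compound 4 is therefore expected to behave in the same way, with an estimated value of 180000 nM, between 60000 nM and 500000 nM. That estimate means an expected step of a number no higher from compound 3 to compound 4 (the limit leaves the size open) that stays within the scatter.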

Compound 4, half-maximal effective concentration: > 170000 nM
Compound 4 ended at the assay's limit; the forecaster's own chance of this, stated with the estimate: 85%; the middle value lies beyond the limit too.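

In this assay compound 4 gives > 170000 nM, which is a limit and not a number, so its steps to compound 1, compound 2 and compound 3 cannot be read. Left open is how much of any of these four compounds is needed for the effect, and whether the group on the aromatic carbon alters that amount at all.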